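The compounds below may be only part of what the source reports. "The series", "measured", "known", "first", "only" and "open" are said of these compounds alone.

Measured values in a functional assay on A549 cells (Homo sapiens) for inhibition, read by MTT assay, with a stated time of 48 h; a higher number here means a weaker inhibitor, a lower number a stronger inhibitor:
compound 1 `CCn1c(/C=C2\SC(=O)N(CC(=O)N3CCCCC3)C2=O)nc2ccccc21` — > 50000 nM
compound 2 `CCn1c(/C=C2\SC(=O)N(CC(=O)N3CCCC3)C2=O)nc2ccccc21` — 31200 nM

The value of compound 1 is a limit of the assay, not a number. Compound 2 stands at the only number shown; the other value in this assay is a limit (the limit of > 50000 nM in this assay, at which 1 of the 2 values shown sits). The measured step of an at least 1.6-fold lower number from compound 1 to compound 2 (0.20 log units; that floor lies within the scatter) accompanied pyrrolidin-1-yl in place of piperidin-1-yl on a carbonyl carbon, and because its floor lies within the scatter an at least 1.6-fold lower number from compound 1 to compound 2 (0.20 log units; that floor lies within the scatter) establishes no real change.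

Compound 3 `CCn1c(/C=C2\SC(=O)N(CC(=O)N3CCOCC3)C2=O)nc2ccccc21` differs from compound 2 by morpholin-4-yl in place of pyrrolidin-1-yl on a carbonyl carbon. Among the compounds with values here, the single measured step bears on it only as another exchange of the ring on the carbonyl carbon, and it was not resolved beyond the scatter. A step in this assay no larger than the scatter is therefore expected, with the chance of a limit kept in mind since one of the two shown values is the limit (the limit of > 50000 nM in this assay, at which 1 of the 2 values shown sits). Compound 3 is estimated at 40000 nM, between 15000 nM and 100000 nM. The expected step is a 1.3-fold higher number from compound 2 to compound 3 (0.11 log units; within the scatter).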

Compound 3, half-maximal inhibitory concentration: > 50000 nM
Compound 3 was reported as a limit; the forecaster's own chance of this, stated with the estimate: 45%; middle value at least 1.2-fold (0.09 log units) away from the limit.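

In this assay compound 3 gives > 50000 nM, which is a limit of the assay and not a number. Morpholin-4-yl in place of pyrrolidin-1-yl on a carbonyl carbon goes with an at least 1.6-fold higher number from compound 2 to compound 3 (0.20 log units; that floor lies within the scatter), so this exchange, like the one from piperidin-1-yl, establishes no real change. The step between compound 1 and compound 3 cannot be read, and compound 2 remains the only compound here with a number: the limit of > 50000 nM in this assay, at which 2 of the 3 values shown sit.

From the compounds shown here alone, whether any group on this carbonyl carbon moves the number beyond the scatter stays open, for example an open-chain diethylamine amide, a piperazin-1-yl ring or a carboxylic acid in place of the ring. Also open, going by these compounds, is whether such a group would give a clear number in this assay rather than a limit.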